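Swapping Furan for Methylpyrrole on a Fused Core

The source may hold more compounds than are shown below. What is called first, only, known or untested is meant among the compounds shown, and "the series" means these compounds.

Within the data shown here, the only measurement in this set is a functional assay on the whole organism (strain Wistar Albino) for inhibition, with Rattus norvegicus as the target, read by paw edema, with a stated time of 2 h, at a dose of 20 mg/kg; on this read-out lower numbers stand for less inhibition and higher numbers for more inhibition at the one dose given (going by the name of the read-out). Compound 1 `COc1ccc(Cc2nnc3n2NC(c2ccco2)S3)cc1OC` gives 17.5% in this assay. Two other compounds carry the same fused core with different groups attached: compound 2 `Cc1occc1-c1nnc2n1NC(c1ccco1)S2` gives 21.6% in this assay, and compound 3 `COc1ccc(Cl)c(-c2nnc3n2NC(c2ccc([N+](=O)[O-])o2)S3)c1` gives 18.5% in this assay. Among the measured compounds shown here, of the three numbers, the one for compound 1 is the smallest, yet the gap to compound 3 and the gap to compound 2 both lie within the usual scatter of repeated measurements, so the three readings cannot be told apart and none of the numbers can be called higher or lower than another.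

Compound 4 `COc1ccc(Cc2nnc3n2NC(c2cccn2C)S3)cc1OC` has not yet been measured. It differs from compound 1 in one place: 1-methyl-1H-pyrrol-2-yl in place of furan-2-yl on a saturated ring carbon. For the measured compounds named here, no pair of the measured compounds differs in only one place, so there is no measured step to lean on. Going by the values given here, all three numbers so far sit together within the scatter, and on that showing a change of this kind is expected to leave the reading within the scatter, with the step of a number 2.5 percentage points higher from compound 1 to compound 4 (within the scatter) expected to be small and in no particular direction. Compound 4 is therefore estimated to give 20% in this assay, within a range from 10% to 30%.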

Compound 4, a percentage reported as inhibition, in the whole organism at one dose (the size of the read-out at that dose, not a potency): 15.8%
Compound 4: the middle estimate sits 4.2 percentage points above what was measured; low and high end bracket the measured number.
By their numbers in this assay, from the lowest: compounds 4, 1, 3 and 2 (each within the scatter of the next).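

Among these compounds, this pair is the first in the set to differ in one place only, so it gives the first direct reading of a change on the saturated ring carbon of the shared core. In this assay the exchange of furan-2-yl for 1-methyl-1H-pyrrol-2-yl gives a number 1.7 percentage points lower from compound 1 to compound 4 (within the scatter) and so produces no change that can be told from ordinary scatter, even though the ring oxygen gives way to a ring nitrogen carrying a methyl group and the counts of hydrogen-bond donors and acceptors stay the same. No supporting evidence is available to explain this outcome.

This single exchange, on one background and at one dose, says nothing about how a group of a different kind would behave at this position, such as an aliphatic amine, a carboxylic acid or a longer alkyl chain. It also leaves open whether the same exchange would read alike with the other groups that compound 2 and compound 3 carry on the shared core.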